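Ester-Bearing Piperidine Replaces a Dimethylamino Chain

The source may hold more compounds than are shown below. What is called first, only, known or untested is meant among the compounds shown, and "the series" means these compounds.

Compound 1, `CN(C)CCCCCCCCCOc1ccc2oc(-c3ccccc3)cc(=O)c2c1`: 334 nM
Compound 2, `CN(C)CCCCCCCCCCOc1ccc2oc(-c3ccccc3)cc(=O)c2c1`: 297 nM
Compound 3, `O=c1cc(-c2ccccc2)oc2ccc(OCCCCCCN3CCC(O)CC3)cc12`: 100 nM

These three compounds share one core and differ only in the amine carried at the end of a chain attached through an oxygen on an aromatic ring. In an assay on isolated protein (Cavia porcellus) with Sigma non-opioid intracellular receptor 1 (Homo sapiens) as the target, read by radioligand binding (a higher number here means a weaker inhibitor, a lower number a stronger inhibitor), compound 1 stands at the high end of the three numbers; its step to compound 2 is a 1.1-fold lower number from compound 1 to compound 2 (0.05 log units; within the scatter), within the scatter, while its step to compound 3 is a 3.3-fold lower number from compound 1 to compound 3 (0.52 log units; beyond the scatter).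

Compound 4, `CCOC(=O)C1CCN(CCCCCCOc2ccc3oc(-c4ccccc4)cc(=O)c3c2)CC1`, has not yet been measured. It differs from compound 1 by 4-(ethoxycarbonyl)piperidin-1-yl in place of 3-(dimethylamino)propyl on a saturated chain carbon, six bonds along the chain from an oxygen on an aromatic ring. For the measured compounds named here, the steps that bear on this change are a 3.3-fold lower number from compound 1 to compound 3 (0.52 log units; beyond the scatter) and a 3.0-fold lower number from compound 2 to compound 3 (0.47 log units; beyond the scatter), both of which exchange an open dimethylamino chain for a ring amine at the same point; both were modest and lowered the number. Going by the values given here, nothing among the measured compounds shows how an ethoxycarbonyl group on that ring compares with the hydroxyl of compound 3, so the expectation rests on those two steps alone. Compound 4 is therefore expected to give 130 nM, somewhere between 45 nM and 400 nM, a step of a 2.6-fold lower number from compound 1 to compound 4 (0.41 log units; beyond the scatter).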

Compound 4, half-maximal inhibitory concentration: 164 nM
The estimate for compound 4 lay 1.3-fold (0.10 log units) below the measured number, within the range that was stated.
By their numbers in this assay, from the lowest: compounds 3, 4, 2 and 1 (each within the scatter of the next, the first and the last beyond it).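

In this assay, for the compounds shown here, ethoxycarbonyl can stand in place of the hydroxy on the ring carbon without a change that exceeds the usual scatter (a 1.6-fold higher number from compound 3 to compound 4 (0.21 log units; within the scatter)), so this position accepts a much larger group than the earlier compounds showed. Against the open-chain amines the picture is less even: the step from the first of them lies beyond the scatter (a 2.0-fold lower number from compound 1 to compound 4 (0.31 log units; beyond the scatter)), while the step from the second does not (a 1.8-fold lower number from compound 2 to compound 4 (0.26 log units; within the scatter)). Nothing measured here gives a reason for these results.

Compounds 3 and 4 carry a shorter chain as well as a ring amine, so the effect of the ring cannot be separated from that of chain length without a dimethylamino group on the same shorter chain. From the compounds shown here alone, it also remains open how a carboxylic acid or an amide in place of the ethyl ester would read.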